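Pentyloxy to benzyloxy on a methoxy-bearing core

The source may hold more compounds than are shown below. What is called first, only, known or untested is meant among the compounds shown, and "the series" means these compounds.

Compound 2 `CCCCCOCNc1n[n+]([O-])c2ccccc2[n+]1[O-]` gives 1220 nM in a functional assay on KB cells (Homo sapiens) for cytotoxicity, read by MTT assay, with a stated time of 72 h; a higher number here means a weaker inhibitor, a lower number a stronger inhibitor. Compound 1 `[O-][n+]1nc(NCOCc2ccccc2)[n+]([O-])c2ccccc21` differs from it by phenyl in place of butyl on a saturated chain carbon bound to an oxygen on a saturated carbon, and compound 1 gives 5720 nM in this assay, so that a 4.7-fold higher number from compound 2 to compound 1 (0.67 log units; beyond the scatter). Compound 3 `CCCCCOCNc1n[n+]([O-])c2cc(OC)ccc2[n+]1[O-]` differs from compound 2 in its core by methoxy in place of hydrogen on an aromatic carbon, and compound 3 gives 2810 nM, so that a 2.3-fold higher number from compound 2 to compound 3 (0.36 log units; beyond the scatter). Compound 4 `COc1ccc2c(c1)[n+]([O-])nc(NCOCc1ccccc1)[n+]2[O-]` is not yet measured; it differs from compound 3 by phenyl in place of butyl on a saturated chain carbon bound to an oxygen on a saturated carbon, the same change as that from compound 2 to compound 1, at the same place. The expected step is a 3.9-fold higher number from compound 3 to compound 4 (0.59 log units; beyond the scatter), because the same change earlier gave a 4.7-fold higher number from compound 2 to compound 1 (0.67 log units; beyond the scatter). Compound 4 is therefore expected to give about 11000 nM in this assay, within a range from 5000 nM to 26000 nM.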

Compound 4, half-maximal inhibitory concentration: 2400 nM
Beside the measured number, compound 4's estimate is 4.6-fold (0.66 log units) above it; the measured number lies below the stated range.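

In this assay, the change from pentyloxy to benzyloxy gave a 1.2-fold lower number from compound 3 to compound 4 (0.07 log units; within the scatter), so the step seen on the core of compound 2 did not carry over to the methoxy-bearing core: the same change on two cores in this assay, a 4.7-fold higher number (0.67 log units; beyond the scatter) from compound 2 to compound 1 and a 1.2-fold lower number (0.07 log units; within the scatter) from compound 3 to compound 4, 5.5-fold (0.74 log units) apart, beyond the scatter of two such steps

Read the other way, methoxy in place of hydrogen gave a 2.4-fold lower number from compound 1 to compound 4 (0.38 log units; beyond the scatter), so its step also depended on the chain present: the same change on two cores in this assay, a 2.3-fold higher number (0.36 log units; beyond the scatter) from compound 2 to compound 3 and a 2.4-fold lower number (0.38 log units; beyond the scatter) from compound 1 to compound 4, 5.5-fold (0.74 log units) apart, beyond the scatter of two such steps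

The two changes therefore did not add up across these four compounds, but this single set does not show why, nor whether the same holds on any other core.

Going by these compounds, it remains open whether chlorine in place of methoxy would likewise alter the step from pentyloxy to benzyloxy. On these data alone, it also remains open whether an amine at the end of the chain would show the same dependence on the core.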